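The source may report more compounds than this note shows. Statements on the series, on what has been measured and on what is new or still open speak of the compounds shown alone.

Measured compounds in a functional assay on UACC-62 cells (Homo sapiens) for antiproliferative activity, read by sulforhodamine B assay, with a stated time of 48 h; on this read-out lower numbers stand for stronger inhibition and higher numbers for weaker inhibition:
- compound 1 `O=C(Nc1ccc(-n2cc(-c3ccncc3)c(-c3ccc(Cl)c(O)c3)n2)cc1)c1ccc(Cl)c(Cl)c1`: 3220 nM
- compound 2 `O=C(Nc1ccc(-n2cc(-c3ccncc3)c(-c3ccc(Cl)c(O)c3)n2)cc1)c1cc(Cl)cc(Cl)c1`: 2730 nM

Compound 2 stands at one of two numbers in this assay, and compound 1 lies within the scatter of it: the change a 1.2-fold lower number from compound 1 to compound 2 (0.07 log units; within the scatter) is within the scatter, so the two numbers cannot be told apart.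

Compound 3 `O=C(Nc1ccc(-n2cc(-c3ccncc3)c(-c3ccc(Cl)c(O)c3)n2)cc1)c1ccc(Cl)c(C(F)(F)F)c1` is not yet measured. It differs from compound 2 by 4-chloro-3-(trifluoromethyl)phenyl in place of 3,5-dichlorophenyl on a carbonyl carbon. Going by the values given here, the one step that bears on this place, the change of the aryl group on the carbonyl carbon, is a 1.2-fold lower number from compound 1 to compound 2 (0.07 log units; within the scatter), which stayed within the scatter. Nothing measured here separates one aryl group on this carbonyl carbon from another, so for compound 3 no step beyond the scatter is expected in this assay in either direction.

Compound 3 is therefore estimated at 2600 nM, with a range from 1000 nM to 6500 nM, which amounts to an expected step of a 1.1-fold lower number from compound 2 to compound 3 (0.02 log units; within the scatter).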

Compound 3, half-maximal inhibitory concentration: 2030 nM
Compound 3: middle estimate off by 1.3-fold (0.11 log units), on the high side; low and high end bracket the measured number.
By their numbers in this assay, from the lowest: compounds 3, 2 and 1 (each within the scatter of the next).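

In this assay, a third aryl group on the carbonyl carbon again gives no separable number: the step is a 1.3-fold lower number from compound 2 to compound 3 (0.13 log units; within the scatter). Trifluoromethyl in place of chloro on an aromatic carbon, a change the earlier pair did not contain, gives a 1.6-fold lower number from compound 1 to compound 3 (0.20 log units; within the scatter), and 4-chloro-3-(trifluoromethyl)phenyl, with 11 heavy atoms against 8 for 3,5-dichlorophenyl, also stays within the scatter. Nothing measured on these compounds speaks to what lies behind these numbers.

Going by these compounds, all three aryl groups carry only chloro or trifluoromethyl, so it stays open whether a carboxylic acid, an amine or a methoxy group on this ring would move the number beyond the scatter. Also open, on these data alone, is whether a saturated alkyl chain in place of the aryl group on the carbonyl carbon would do so.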